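Compound 4 and a cytotoxicity read-out held at limits

The compounds below may be only part of what the source reports. "The series", "measured", "known", "first", "only" and "open" are said of these compounds alone.

In an ADME assay on Huh7.5.1 cells (Homo sapiens) for cytotoxicity, read by WST assay, with a stated time of 48 h (a lower number here means that less compound is tolerated, a higher number that more compound is tolerated), compound 3 (`Cc1c(-c2ccc(Cc3ccc(OC(F)F)cc3)cc2)[nH]c2cccc(F)c2c1=O`) gives > 5000 nM as a limit, not a number. Compound 1 (`Cc1c(-c2ccc(Cc3ccc(OCC(F)(F)F)cc3)cc2)[nH]c2cccc(F)c2c1=O`) gives > 5000 nM as a limit too. Compound 2 (`Cc1c(-c2ccc(Cc3ccc(C(O)C(F)(F)F)cc3)cc2)[nH]c2cccc(F)c2c1=O`) gives > 10000 nM as a limit as well.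

Compound 4 (`COc1ccc(Cc2ccc(-c3[nH]c4cccc(F)c4c(=O)c3C)cc2)cc1`) departs from compound 3 through methyl in place of difluoromethyl on an oxygen on an aromatic ring in one place: methyl in place of difluoromethyl on an oxygen on an aromatic ring.

Going by the values given here, three measured steps bear on this group. The closest, at the same oxygen, is a step that the two limits leave unreadable from compound 1 to compound 3 and it gives no usable size. Also bearing on it are a step that the two limits leave unreadable from compound 1 to compound 2 and a step that the two limits leave unreadable from compound 2 to compound 3 without any usable size either. All three measured compounds stay at limits in this assay so no direction can be drawn from them. Only a change within the scatter is therefore expected, estimated as a step that the limit leaves unreadable from compound 3 to compound 4 in this read-out. Compound 4 is expected near 8000 nM with an estimated range from 3000 nM to 20000 nM. Compound 4 may again give only a limit.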

Compound 4, half-maximal cytotoxic concentration: > 10000 nM
Compound 4: a limit, no number (the forecaster's own chance of this, stated with the estimate: 80%); at least 1.2-fold (0.09 log units) between middle value and limit.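

Compound 4 also stays at a limit, so its steps to compound 1, compound 2 and compound 3 cannot be read. The compounds shown leave open what concentration each one actually tolerates and whether the exchanged groups differ in cytotoxicity at all.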